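The source may hold more compounds than are shown below. What is called first, only, known or untested is meant among the compounds shown, and "the series" means these compounds.

Measured compounds:
compound 1, `CC(C)N(C(=O)CN1C=CN(c2ccccc2)C(=O)[C@H](Cc2n[nH]c3ccccc23)C1=O)c1ccccc1`, with 295 nM;
compound 2, `COc1ccc(N(C(=O)CN2C=CN(c3ccccc3)C(=O)[C@H](Cc3n[nH]c4ccccc34)C2=O)C(C)C)cc1`, with 15.9 nM;
compound 3, `COc1ccc(N(C(=O)CN2C=CN(c3ccccc3)C(=O)C(Cc3n[nH]c4cc(F)ccc34)C2=O)C(C)C)cc1`, with 1.59 nM.

All three were tested in a functional assay on CHO cells for agonist activity at Melanocyte-stimulating hormone receptor (Homo sapiens), read by a luciferase reporter, with a stated time of 4 h; on this read-out lower numbers stand for an effect already at smaller amounts and higher numbers for an effect only at larger amounts of compound. Compound 2 and compound 1 share a core and differ in one place, (hydrogen in place of methoxy on an aromatic carbon). That single change made a step of a 19-fold higher number from compound 2 to compound 1 (1.27 log units; beyond the scatter), so within this pair the removal of the methoxy group moved the number far beyond the usual scatter. Compound 3 stands lowest of the three; the difference between its core and that of compound 2 is not broken down here, so only the two values themselves can be compared, and they lie well apart.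

Compound 4, `CC(C)N(C(=O)CN1C=CN(c2ccccc2)C(=O)C(Cc2n[nH]c3cc(F)ccc23)C1=O)c1ccccc1`, has not yet been measured. It differs from compound 3 by hydrogen in place of methoxy on an aromatic carbon. Within the data shown here, this is the same change as the one from compound 2 to compound 1, at a place that is described in the same words, with the only other distinction lying in the core onto which it is made.

The expectation for compound 4 in this assay therefore rests on compound 2 and compound 1 and the step of a 19-fold higher number from compound 2 to compound 1 (1.27 log units; beyond the scatter) between them: a step of about the same size is expected, a 19-fold higher number from compound 3 to compound 4 (1.28 log units; beyond the scatter). On that basis compound 4 is estimated at 30 nM, most likely between 8 nM and 110 nM, the wider band reflecting that the change has been seen on one core only and that the core of compound 3 is not the core of compound 2.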

Compound 4, half-maximal effective concentration: 186 nM
For compound 4 the middle estimate is 6.2-fold (0.79 log units) below the measured one; the measured number lies above the stated range.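

In this assay, hydrogen in place of methoxy again produced a large step, a 120-fold higher number from compound 3 to compound 4 (2.07 log units; beyond the scatter). The direction of the change therefore carried over from one core to the other, but its size did not, so the two steps cannot be treated as a single fixed increment: the same change on two cores in this assay, a 19-fold higher number (1.27 log units; beyond the scatter) from compound 2 to compound 1 and a 120-fold higher number (2.07 log units; beyond the scatter) from compound 3 to compound 4, 6.3-fold (0.80 log units) apart, beyond the scatter of two such steps In both pairs the compound with the methoxy group on the aromatic carbon para to a large group has the lower number, and the size of the step differs with the core; this does not show which feature of the two cores sets that size, and two pairs are too few to predict the step on any further core.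

The compounds shown carry only methoxy or hydrogen at this place, so it remains open how an ethoxy group, a hydroxyl group or a chlorine atom there would read. From the compounds shown here alone, it also remains open whether the step would stay as large on the core of compound 3 if a longer chain stood in place of the isopropyl group.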